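Chloro in Place of Fluoro: Expected Agonist Activity

The source may report more compounds than this note shows. Statements on the series, on what has been measured and on what is new or still open speak of the compounds shown alone.

Compound 1 `Nc1scc(-c2cccc(C(F)(F)F)c2)c1C(=O)c1ccc(Cl)cc1` in a functional assay on CHO cells for agonist activity at adenosine receptor A1 (Homo sapiens), read by fluorescence and ERK phosphorylation, with stated times of 30 min and 1.5 h, tested at 3 uM (on this read-out lower numbers stand for a weaker effect and higher numbers for a stronger effect at the one concentration tested), gives 64%.
Compound 2 `Nc1scc(-c2cccc(F)c2)c1C(=O)c1ccc(Cl)cc1` in this assay gives 76%.

Compound 2 stands highest of the two numbers, with compound 1 nearest, the gap being a number 12 percentage points higher from compound 1 to compound 2 (beyond the scatter). Compound 3 `Nc1scc(-c2cccc(Cl)c2)c1C(=O)c1ccc(Cl)cc1` differs from compound 2 by chloro in place of fluoro on an aromatic carbon. For the measured compounds named here, the one measured step, a number 12 percentage points higher from compound 1 to compound 2 (beyond the scatter), touches the same place with other groups and was modest, so it bears only loosely here. The step from compound 2 to compound 3 is expected to be small, a number 5 percentage points lower from compound 2 to compound 3 (within the scatter), likely within the scatter. Compound 3 is estimated at 71%, between 56% and 86%.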

Compound 3, a percentage reported as activity, at one concentration (the size of the read-out at that concentration, not a potency): 58%
Estimate against measurement, compound 3: 13 percentage points above; low and high end bracket the measured number.
By their numbers in this assay, from the lowest: compounds 3 and 1 (each within the scatter of the next); then compound 2.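

In this assay the 3-fluorophenyl to 3-chlorophenyl change gives a number 18 percentage points lower from compound 2 to compound 3 (beyond the scatter) and so shows that this position tells these two halogens apart. Chloro and trifluoromethyl do not separate, with a number 6 percentage points lower from compound 1 to compound 3 (within the scatter) as the step between them, so among these three compounds only the fluoro of compound 2 stands apart. Nothing at hand says why.

Still open, on these data alone, is how a methoxy or an amine at this place would read. Each number also comes from a single concentration, so the potency of these compounds remains unknown.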